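Moving the amino group on a thiazolidinedione side chain

The source may report more compounds than this note shows. Statements on the series, on what has been measured and on what is new or still open speak of the compounds shown alone.

Of the compounds shown here, two have been measured in a functional assay on FM3A cells (Mus musculus) for cytotoxicity, read by cell counting, with a stated time of 2 days; a higher number here means a weaker inhibitor, a lower number a stronger inhibitor. Compound 1, `CC(C)(C)c1ccc(CN2C(=O)S/C(=C\c3ccc(N)cc3)C2=O)cc1`, gives 80000 nM. Compound 2, `Cc1ccc(CN2C(=O)S/C(=C\c3cccc(N)c3)C2=O)cc1`, gives 158000 nM. Of the two numbers, compound 2 holds the higher one, though the gap to compound 1 lies within the usual scatter of repeated measurements, so the two cannot be told apart on these data.

Compound 3, `Cc1ccc(CN2C(=O)S/C(=C\c3ccc(N)cc3)C2=O)cc1`, has not yet been measured. It differs from compound 2 in one place: 4-aminophenyl in place of 3-aminophenyl on a double-bonded chain carbon bound to a double-bonded ring carbon. Within the data shown here, no measured pair in this set isolates that change, so the expectation rests on compound 1, which carries the same 4-aminophenyl group and gives 80000 nM, and on compound 2 itself. Since those two values are indistinguishable, no step beyond the scatter is expected in this assay, in either direction. Compound 3 is therefore estimated to give about 110000 nM, with a plausible range from 40000 nM to 300000 nM. This corresponds to an expected step of a 1.4-fold lower number from compound 2 to compound 3 (0.16 log units; within the scatter).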

Compound 3, half-maximal inhibitory concentration: > 250000 nM
Compound 3: only a limit was reported; the forecaster's own chance of this, stated with the estimate: 15%; at least 2.2-fold (0.35 log units) between middle value and limit.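

Compound 3 carries only a limit in this assay, not a number, and that limit sets the floor of both of its steps: the limit of > 250000 nM in this assay, at which 1 of the 3 values shown sits. Putting 4-aminophenyl in place of 3-aminophenyl gives an at least 1.5-fold higher number from compound 2 to compound 3 (0.19 log units; that floor lies within the scatter), so moving the amino group is not shown to change the number, although a larger step remains possible. Among these compounds, the clearer news comes from the other place: with 4-aminophenyl kept, methyl in place of tert-butyl on an aromatic carbon gives an at least 3.1-fold higher number from compound 1 to compound 3 (0.49 log units; beyond the scatter), the first step in this set to clear the scatter, which shows that the group at that place matters in this assay.

As far as these compounds go, how far compound 3 really lies beyond its limit stays unknown, so the full size of both steps stays unknown too. The compounds shown also leave open whether ethyl or isopropyl in place of the methyl would bring the number back towards that of compound 1, and what a hydroxyl group or a carboxylic acid in place of the amino group would do.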